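Chloro in Place of Methoxycarbonyl: Expecting Another Limit

The source may hold more compounds than are shown below. What is called first, only, known or untested is meant among the compounds shown, and "the series" means these compounds.

Compound 1 `O=C(Cn1cc(-c2ccccc2Cl)nn1)Nc1nc2ccccc2s1` gives > 30000 nM in a functional assay on BMDM cells (Mus musculus, strain C57BL/6) for inhibition, with a stated time of 2 days (a lower number here means a stronger inhibitor, a higher number a weaker inhibitor), a limit.
Compound 2 `N#Cc1ccc(-c2cn(CC(=O)Nc3nc4ccccc4s3)nn2)cc1` gives > 30000 nM in this assay, a limit.
Compound 3 `COC(=O)c1ccc(-c2cn(CC(=O)Nc3nc4ccccc4s3)nn2)cc1` gives > 30000 nM in this assay, a limit.

Compound 3 therefore stands at the limit of > 30000 nM in this assay, at which 3 of the 3 values shown sit, so its value is a limit and not a number. The two measured steps that bear on the series, a step that the two limits leave unreadable from compound 1 to compound 2 and a step that the two limits leave unreadable from compound 2 to compound 3, give no readable size and no direction. Compound 4 `O=C(Cn1cc(-c2ccc(Cl)cc2)nn1)Nc1nc2ccccc2s1` differs from compound 3 by chloro in place of methoxycarbonyl on an aromatic carbon. With no readable step available, no size of step beyond the scatter can be predicted in this assay. Compound 4 is estimated at 40000 nM, with a range from 10000 nM to 200000 nM, and most likely reported again only as a limit. The estimated step is a step that the limit leaves unreadable from compound 3 to compound 4.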

Compound 4, half-maximal inhibitory concentration: 130 nM
Beside the measured number, compound 4's estimate is 310-fold (2.49 log units) above it; measured number outside the range, below it.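

In this assay, within the data shown here, chloro on this aromatic carbon, para to a large group, yields the first number of the series rather than a limit, with an at least 230-fold lower number from compound 3 to compound 4 (2.36 log units; beyond the scatter). Chloro in place of cyano reads the same way, with an at least 230-fold lower number from compound 2 to compound 4 (2.36 log units; beyond the scatter). The 4-chlorophenyl group also differs from 2-chlorophenyl, with an at least 230-fold lower number from compound 1 to compound 4 (2.36 log units; beyond the scatter), so the presence of a chloro on the ring is not enough on its own.

From the compounds shown here alone, the true size of these steps stays open, as the other compounds give only a limit: the limit of > 30000 nM in this assay, at which 3 of the 4 values shown sit. Going by these compounds, how a methyl, a bromo or an amine would read in place of this chloro also remains open.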